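A few compounds are considered here, and "the series" means these few. Any claim that something is new, unique, unknown or untested is made for them only; others in the source may bear on it.

Compound 3 `Cc1ccc2c(c1)[n+]([O-])c(NCCN(C)C)n[n+]2[O-]` and compound 4 `Cc1ccc2c(c1)[n+]([O-])c(NCCN1CCCCC1)n[n+]2[O-]` share one core, and compound 4 has not yet been measured in a physicochemical assay for solubility, in the presence of a further agent that is not named here; a higher number here means a more soluble compound, a lower number a less soluble compound. Three compounds have values there. Compound 1 `CN(C)CCNc1n[n+]([O-])c2ccccc2[n+]1[O-]` gives 50000000 nM in this assay. Compound 2 `[O-][n+]1nc(NCCN2CCCCC2)[n+]([O-])c2cc(Cl)ccc21` gives 3200000 nM in this assay. Compound 3 stands at a limit of this assay, reported as > 51000000 nM and therefore known only as a floor rather than a number. Within the data shown here, the one single-site step among the measured compounds is an at least 1.0-fold higher number from compound 1 to compound 3 (0.00 log units; that floor lies within the scatter), and its true size stays open because compound 3 sits at the limit of > 51000000 nM in this assay, at which 1 of the 3 values shown sits.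

Compound 4 carries piperidin-1-yl in place of dimethylamino on a saturated chain carbon, two bonds along the chain from a nitrogen on an aromatic ring. Among the measured compounds shown here, no measured pair of compounds shows this change on its own. For the measured compounds named here, compound 2 carries piperidin-1-yl where compound 1 carries dimethylamino, but the two also differ in a second place, so their values show only that compound 2 gives the lower number and compound 1 the higher. On that thin basis the step expected from compound 3 to compound 4 in this assay is an at least 2.0-fold lower number from compound 3 to compound 4 (0.30 log units; that floor lies within the scatter), modest and downward but uncertain. Compound 4 is therefore estimated at 25000000 nM in this assay, within a range from 6000000 nM to 51000000 nM, with a real chance that this assay again reports only a limit.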

Compound 4, solubility: 45000000 nM
For compound 4 the middle estimate is 1.8-fold (0.26 log units) below the measured one, within the range that was stated.
By their numbers in this assay, from the lowest: compound 2; then compounds 4 and 1 (each within the scatter of the next). At a limit, above all of these: compound 3.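

Among these compounds, with piperidin-1-yl held fixed on the chain, methyl in place of chloro on an aromatic carbon gives a 14-fold higher number from compound 2 to compound 4 (1.15 log units; beyond the scatter), the first single-site step in this set that clearly exceeds the scatter in this assay. The change at the chain position can now be seen on its own: piperidin-1-yl in place of dimethylamino, on a saturated chain carbon two bonds along the chain from a nitrogen on an aromatic ring, gives an at least 1.1-fold lower number from compound 3 to compound 4 (0.05 log units; that floor lies within the scatter). That figure is only a floor, and the true size of the step stays unknown because compound 3 is reported at a limit: the limit of > 51000000 nM in this assay, at which 1 of the 4 values shown sits.

So the compounds shown do not settle whether this swap of chain groups changes the read-out by a little or by a lot, and the effect of chloro and methyl has been compared only with piperidin-1-yl on the chain. They also leave open how other amines on the same chain, such as morpholin-4-yl or diethylamino, or other aromatic substituents, such as fluoro or methoxy, would read in this assay.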